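The source may report more compounds than this note shows. Statements on the series, on what has been measured and on what is new or still open speak of the compounds shown alone.

Compound 1 `O=C(CCCCCCc1ccccc1)c1nc(C(=O)C(F)(F)F)co1` carries a trifluoromethyl group on a carbonyl carbon attached to its core. In an assay on HEK-293T cells for inhibition of diacylglycerol lipase-alpha (Homo sapiens), read by colorimetric assay (on this read-out lower numbers stand for stronger inhibition and higher numbers for weaker inhibition), compound 1 gives 123 nM. Compound 2 `CC(=O)c1coc(C(=O)CCCCCCc2ccccc2)n1` differs from compound 1 by methyl in place of trifluoromethyl on a carbonyl carbon; in this assay compound 2 gives 123 nM, and the step of no change at the digits printed from compound 1 to compound 2 (within the scatter) shows that exchanging the two groups left the read-out where it stood.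

Compound 3 `O=C(CCCCCCc1ccccc1)c1ncc(C(=O)C(F)(F)F)o1` is built from the same atoms as compound 1, joined differently; the difference between the two cores is not broken down here. In this assay compound 3 gives 1820 nM, whereas compound 1 gives 123 nM, so the rearranged core of compound 3 sits well to the weaker side.

Compound 4 `CC(=O)c1cnc(C(=O)CCCCCCc2ccccc2)o1` stands to compound 3 as compound 2 stands to compound 1: it differs by methyl in place of trifluoromethyl on a carbonyl carbon, with the same surroundings at the carbonyl carbon. Within the data shown here, since that change left compound 1 unmoved on the way to compound 2, the expected step from compound 3 to compound 4 is a 1.0-fold lower number from compound 3 to compound 4 (0.00 log units; within the scatter), essentially flat, resting on the single earlier example no change at the digits printed from compound 1 to compound 2 (within the scatter). On that basis compound 4 is expected to give 1800 nM in this assay, with the estimate bounded between 700 nM and 4500 nM, close to the figure of compound 3 1820 nM.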

Compound 4, half-maximal inhibitory concentration: > 10000 nM
Compound 4: only a limit was reported; the forecaster's own chance of this, stated with the estimate: 5%; at least 5.5-fold (0.74 log units) between middle value and limit.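

The exchange of trifluoromethyl for methyl on a carbonyl carbon did not behave alike on the two cores in this assay: the same change on two cores in this assay, no change at the digits printed (within the scatter) from compound 1 to compound 2 and an at least 5.4-fold higher number (0.73 log units; beyond the scatter) from compound 3 to compound 4, at least 5.4-fold (0.73 log units) apart, beyond the scatter of two such steps

On the core of compound 3 the exchange gave an at least 5.4-fold higher number from compound 3 to compound 4 (0.73 log units; beyond the scatter), whereas on the core of compound 1 it gave no change at the digits printed from compound 1 to compound 2 (within the scatter), so the flat result from the first pair cannot be carried over to the second, and the effect of this change in the series depends on the core it is made on. Among these compounds, compound 4 gives > 10000 nM, which is a limit of the assay and not a number, so the pair shows that the two cores part ways but not how far, and with only two cores it gives no rule for any other core and no reason for the difference.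

The compounds shown leave open how a difluoromethyl group, an ethyl group or an amine on that carbonyl carbon would read on either core, and so whether the gap is peculiar to trifluoromethyl and methyl. They also leave open whether the same gap between the two cores would persist with a shorter or longer chain in place of the one that carries the phenyl ring.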